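The compounds below may be only part of what the source reports. "The series", "measured", "known", "first", "only" and "open" are said of these compounds alone.

Three compounds share a core in which an amide-linked propanamide bearing a methanesulfonamide and a fluorine sits on one side and a trifluoromethyl-substituted aromatic ring on the other. Compound 1 `Cc1ccc(Nc2nc(C(F)(F)F)ccc2CNC(=O)C(C)c2ccc(NS(C)(=O)=O)c(F)c2)cc1C` gives 1160 nM in a functional assay on CHO-K1 cells for antagonist activity at transient receptor potential cation channel subfamily V member 1 (Homo sapiens), read by FLIPR; a higher number here means a weaker inhibitor, a lower number a stronger inhibitor. Compound 2 `Cc1ccc(Cl)cc1Nc1nc(C(F)(F)F)ccc1CNC(=O)C(C)c1ccc(NS(C)(=O)=O)c(F)c1` gives 140 nM in this assay, and compound 3 `CC(C(=O)NCc1ccc(C(F)(F)F)nc1NCc1ccccc1)c1ccc(NS(C)(=O)=O)c(F)c1` gives 203 nM. Compound 3 thus has the second highest of the three numbers; it sits close to compound 2, with a 1.5-fold higher number from compound 2 to compound 3 (0.16 log units; within the scatter), and well apart from compound 1, with a 5.7-fold lower number from compound 1 to compound 3 (0.76 log units; beyond the scatter).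

Compound 4 `CC(C(=O)NCc1ccc(C(F)(F)F)nc1N(C)C)c1ccc(NS(C)(=O)=O)c(F)c1` differs from compound 3 in one place: dimethylamino in place of benzylamino on an aromatic carbon. The measured steps at this nitrogen all kept an aromatic ring and the hydrogen on the nitrogen and moved the number only modestly, as in an 8.3-fold lower number from compound 1 to compound 2 (0.92 log units; beyond the scatter) and a 5.7-fold lower number from compound 1 to compound 3 (0.76 log units; beyond the scatter). For the measured compounds named here, compound 4 removes both the ring and that hydrogen, and no measured step covers such a loss. The estimate for compound 4 in this assay is therefore 800 nM, within a range of 200 nM to 3200 nM. This expected step, a 3.9-fold higher number from compound 3 to compound 4 (0.60 log units; beyond the scatter), is a weakening beyond the scatter, held with little confidence.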

Compound 4, half-maximal inhibitory concentration: 2390 nM
The estimate for compound 4 lay 3.0-fold (0.48 log units) below the measured number; the range from low to high includes it.
By their numbers in this assay, from the lowest: compounds 2 and 3 (each within the scatter of the next); then compound 1; then compound 4.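

Among the groups on this nitrogen, dimethylamino is the only one without a ring and without a hydrogen on the nitrogen, and it stands well apart from two of the others in this assay: a 12-fold higher number from compound 3 to compound 4 (1.07 log units; beyond the scatter) and a 17-fold higher number from compound 2 to compound 4 (1.23 log units; beyond the scatter). The step from the (3,4-dimethylphenyl)amino group is much smaller, a 2.1-fold higher number from compound 1 to compound 4 (0.31 log units; beyond the scatter), so the cost of this change depends on which group leaves, and the position tolerates neither all ring-bearing groups equally nor the loss of the ring and that hydrogen together. Nothing in the available data accounts for the size of these steps.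

On these data alone, the ring and the hydrogen leave together in compound 4, so their shares in the loss stay open: methylamino would keep the hydrogen without the ring, and benzyl(methyl)amino would keep the ring without the hydrogen. Also open, as far as these compounds go, is whether the ring must be aromatic, which cyclohexylamino, with a saturated ring and the hydrogen on the nitrogen, would address.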